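The compounds below may be only part of what the source reports. "The series", "measured", "known", "first", "only" and "open" are said of these compounds alone.

Measured compounds so far:
- compound 1 `CO/N=C(\C)COc1ccc2c(=O)c(-c3ccccc3)coc2c1` gives 6400000 nM in a functional assay on SK-HEP1 cells (Homo sapiens) for antiproliferative activity; a lower number here means a stronger inhibitor of growth, a higher number a weaker inhibitor of growth
- compound 2 `O=c1c(-c2ccccc2)coc2cc(OC/C(=N/O)c3ccccc3)ccc12` gives 6400000 nM in this assay

Within the data shown here, compound 2 stands level with compound 1: the one step measured, no change at the digits printed from compound 1 to compound 2 (within the scatter), brought no change beyond the scatter, although it replaced a small chain with a larger group that carries an aromatic ring. Compound 3 `CO/N=C(/COc1ccc2c(=O)c(-c3ccccc3)coc2c1)c1ccccc1` differs from compound 2 by methyl in place of hydrogen on an oxygen; cut one bond further out, the change reads hydroxy to methoxy. Among the measured compounds shown here, no measured step touches this oxygen, so the only guide is the step from compound 1 to compound 2, which changed nothing even with a much larger swap. On that basis the step of no change at the digits printed from compound 2 to compound 3 (within the scatter) is expected to be none beyond the scatter. Compound 3 is therefore estimated at 6400000 nM, with a range from 2000000 nM to 10000000 nM.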

Compound 3, concentration for 50% growth inhibition: 7400000 nM
Beside the measured number, compound 3's estimate is 1.2-fold (0.06 log units) below it; the range from low to high includes it.
By their numbers in this assay, from the lowest: compounds 1, 2 and 3 (each within the scatter of the next).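

Methyl in place of hydrogen on an oxygen whose other neighbour is a double-bonded nitrogen gives a 1.2-fold higher number from compound 2 to compound 3 (0.06 log units; within the scatter) in this assay, so the hydroxy to methoxy change, the first change seen at this oxygen, leaves the read-out within the scatter. With the methoxy kept in both compounds, phenyl in place of methyl on the carbon with a double bond to nitrogen gives a 1.2-fold higher number from compound 1 to compound 3 (0.06 log units; within the scatter), which shows this swap alone, where the earlier step also altered the oxygen. No measurement shown here offers an explanation for how close these numbers lie.

From the compounds shown here alone, all three compounds lie within the scatter of each other, so it remains open whether any change at these two places can move the number beyond it. A longer chain on that oxygen, or an amine or a carboxylic acid on the phenyl, might answer this.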